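This account rests on a few compounds, and the source may have more. Where it says the series, first, only, none or still open, it means among the compounds named here.

In a functional assay on PC-3 cells (Homo sapiens) for cytotoxicity, read by MTT assay, with a stated time of 72 h (on this read-out higher numbers stand for weaker inhibition and lower numbers for stronger inhibition), compound 3 `Cc1cc(=O)n(-c2ccccc2C(F)(F)F)nc1C(=O)Nc1ccc(Oc2ncnc3c2ccn3C)cc1` gives 19100 nM. Compound 1 `Cc1cc(=O)n(-c2ccc(Br)cc2F)nc1C(=O)Nc1ccc(Oc2ncnc3c2ccn3C)cc1` gives 18800 nM, and these two values sit level, with a 1.0-fold higher number from compound 1 to compound 3 (0.01 log units; within the scatter). Compound 2 `Cc1ccc(-n2nc(C(=O)Nc3ccc(Oc4ncnc5c4ccn5C)cc3)c(C)cc2=O)cc1` returns only a limit of the assay, > 60000 nM. The comparison with that limit gives an at least 3.1-fold lower number from compound 2 to compound 3 (0.49 log units; beyond the scatter), so compound 3 stands with compound 1 on the stronger side of this small set.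

Compound 4 `Cc1cc(=O)n(-c2ccccc2C(F)(F)F)nc1C(=O)Nc1ccc(Oc2ncnc3c2ccn3C)c(F)c1` keeps all of compound 3 except for one spot: fluoro in place of hydrogen on an aromatic carbon, ortho to a large group and meta to a large group (fluoro in place of hydrogen on an aromatic carbon). Among the measured compounds shown here, all the measured steps change the group on an aromatic nitrogen, so none of them tests this ring directly. They serve only as a rough guide to size. Replacing one substituted phenyl group with another gave an at least 3.1-fold higher number from compound 1 to compound 2 (0.50 log units; beyond the scatter) in one case, but no change beyond the scatter in the case of compound 3, at a 1.0-fold higher number from compound 1 to compound 3 (0.01 log units; within the scatter). A single fluoro is a smaller alteration than those swaps, so a large jump seems unlikely. The expected change is a 1.3-fold lower number from compound 3 to compound 4 (0.10 log units; within the scatter), which stays within the scatter and leans only slightly towards stronger inhibition. The estimate for compound 4 is 15000 nM, with an expected range from 6000 nM to 40000 nM.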

Compound 4, half-maximal inhibitory concentration: 25900 nM
Beside the measured number, compound 4's estimate is 1.7-fold (0.24 log units) below it; measured number inside the range.
By their numbers in this assay, from the lowest: compounds 1, 3 and 4 (each within the scatter of the next). At a limit, above all of these: compound 2.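

In this assay, fluoro in place of hydrogen gives a 1.4-fold higher number from compound 3 to compound 4 (0.13 log units; within the scatter), so the two compounds sit level and this small change leaves the read-out within its usual noise. Among the compounds shown here, every earlier step changed the group on an aromatic nitrogen, so this is the first direct test of the six-membered aromatic ring of carbon only, and at this spot, ortho to a large group and meta to a large group, a fluoro can replace hydrogen with no change that can be told apart from the scatter. The one limit in the set still belongs to compound 2: the limit of > 60000 nM in this assay, at which 1 of the 4 values shown sits.

This single result says nothing about what a larger group at the same spot, such as a chlorine, a methoxy group or an amine, would do to the number. It also leaves open whether the same fluoro would sit just as level when paired with the 4-bromo-2-fluorophenyl group of compound 1, or whether its outcome depends on the 2-(trifluoromethyl)phenyl group that compound 3 and compound 4 share.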